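This account rests on a few compounds, and the source may have more. Where it says the series, first, only, none or still open, it means among the compounds named here.

Compound 1 `CC(=O)c1nc([N+](=O)[O-])c(Sc2c(Cl)cncc2Cl)s1` is the reference point of this small set. In an assay on isolated protein for inhibition of ubiquitin carboxyl-terminal hydrolase 7 (Homo sapiens), read by fluorescence, with stated times of 30 min and 3 h (on this read-out lower numbers stand for stronger inhibition and higher numbers for weaker inhibition), compound 1 gives 670 nM, the lowest of the three numbers recorded. Compound 2 `CC(=O)c1nc([N+](=O)[O-])c(Sc2c(Cl)cccc2Cl)s1`, which carries a benzene ring in place of the pyridine of the shared core, gives 4490 nM in this assay, and compound 3 `CCCC(=O)OC(C)c1nc([N+](=O)[O-])c(Sc2c(Cl)cncc2Cl)s1` gives 4490 nM. Among the compounds with values here, the one step that alters the acetyl group, a 6.7-fold higher number from compound 1 to compound 3 (0.83 log units; beyond the scatter), is the only measured change at that position.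

Compound 4 `O=C(NCc1ccccc1)c1nc([N+](=O)[O-])c(Sc2c(Cl)cncc2Cl)s1` differs from compound 1 at the same position: benzylamino in place of methyl on a carbonyl carbon, on a carbonyl carbon whose other neighbour is an aromatic carbon. The step from compound 1 to compound 3 bears on this change, since it also replaces the methyl of the acetyl group, and it gave a modest rise in the number beyond the scatter. Within the data shown here, no measured compound carries an amide at this position, so the direction is taken from that single step. Compound 4 is therefore expected to show a 3.7-fold higher number from compound 1 to compound 4 (0.57 log units; beyond the scatter), and its estimated value is 2500 nM, within a range from 700 nM to 9000 nM.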

Compound 4, half-maximal inhibitory concentration: 4210 nM
Estimate against measurement, compound 4: 1.7-fold (0.23 log units) below, and the stated range covers the measured number.
By their numbers in this assay, from the lowest: compound 1; then compounds 4, 2 and 3 (each within the scatter of the next).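

With the carbonyl kept in place, benzylamino in place of methyl on this carbonyl carbon still gives a 6.3-fold higher number from compound 1 to compound 4 (0.80 log units; beyond the scatter) in this assay. The rise seen earlier therefore does not depend on losing the acetyl carbonyl from the aromatic carbon, and both replacements of the acetyl group shown, in compound 3 and compound 4, end within the scatter of each other, with neither going against this. Nothing available explains the rise, as no supporting evidence bears on this result.

The compounds shown do not separate the contribution of the amide hydrogen from that of the phenyl ring within benzylamino, so a plain amino or methylamino group on this carbonyl carbon remains an open case. Going by these compounds, an ethyl group there, which would extend the acetyl chain by a single carbon, is equally open.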